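A few compounds are considered here, and "the series" means these few. Any claim that something is new, unique, unknown or untested is made for them only; others in the source may bear on it.

Series, an assay on CHO cells for binding affinity to D(4) dopamine receptor (Homo sapiens); a lower number here means a stronger inhibitor, a higher number a weaker inhibitor:
compound 1 `Cc1ccnc(N2CCN(CCC3NC(=O)c4ccccc43)CC2)c1` gives 22.6 nM
compound 2 `O=C1NC(CCN2CCN(c3ccccc3)CC2)c2ccccc21` gives 24.5 nM
compound 3 `O=C1NC(CCN2CCN(c3ccc(Cl)cc3)CC2)c2ccccc21` gives 27.8 nM

Compound 3 carries the highest of the three numbers, but its gaps to compound 2 and to compound 1 are both within the scatter, so no order among the three can be read from these values. The step to compound 4 `COc1ccc(N2CCN(CCC3NC(=O)c4ccccc43)CC2)cc1` is methoxy in place of chloro on an aromatic carbon. The measured steps that bear on it are the exchanges at the same aromatic carbon and at the ring nitrogen: a 1.1-fold higher number from compound 2 to compound 3 (0.05 log units; within the scatter), a 1.1-fold higher number from compound 1 to compound 2 (0.04 log units; within the scatter) and a 1.2-fold higher number from compound 1 to compound 3 (0.09 log units; within the scatter), each within the scatter. Every replacement tried on this part of the molecule has left the number where it was. For the measured compounds named here, no measured compound shows what methoxy itself does at this carbon, so the expectation rests only on the flat run of these steps. For compound 4 the expected step is a 1.1-fold lower number from compound 3 to compound 4 (0.05 log units; within the scatter), none beyond the scatter. Compound 4 is therefore estimated at 25 nM, with a range from 10 nM to 65 nM.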

Compound 4, inhibition constant: 37.3 nM
Compound 4: the middle estimate sits 1.5-fold (0.17 log units) below what was measured; low and high end bracket the measured number.
By their numbers in this assay, from the lowest: compounds 1, 2, 3 and 4 (each within the scatter of the next).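

In this assay methoxy on this aromatic carbon, para to a large group, stays within the scatter of chloro (a 1.3-fold higher number from compound 3 to compound 4 (0.13 log units; within the scatter)) and of hydrogen (a 1.5-fold higher number from compound 2 to compound 4 (0.18 log units; within the scatter)). For the compounds shown here, replacing 4-methylpyridin-2-yl with 4-methoxyphenyl on the ring nitrogen also stays within the scatter (a 1.7-fold higher number from compound 1 to compound 4 (0.22 log units; within the scatter)), so the flat run now extends to methoxy, the only group at this carbon with a hydrogen-bond acceptor. No supporting measurement bears on this result.

Still open, on these data alone, is whether any group on this carbon can move the number beyond the scatter, for example an amine, a carboxylic acid or a longer alkoxy chain in place of methoxy. The compounds shown also vary only this end of the molecule, so the effect of changes to the ethyl link or the shared core remains untested.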